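A Pyridine Ring Replaces a Fluorophenyl Group

The source may hold more compounds than are shown below. What is called first, only, known or untested is meant among the compounds shown, and "the series" means these compounds.

Measured in a functional assay on HT-29 cells (Homo sapiens) for inhibition, with a stated time of 72 h; on this read-out higher numbers stand for weaker inhibition and lower numbers for stronger inhibition:
- compound 1 `COc1ccc(S(=O)(=O)N2CCc3cccc(-c4ccc([N+](=O)[O-])cc4)c32)cc1`: 51.8 nM
- compound 2 `COc1ccc(S(=O)(=O)N2CCc3cccc(-c4cccc(F)c4)c32)cc1`: 119 nM

Of these two numbers, the higher belongs to compound 2 at 119 nM, so it is the weaker inhibitor of the pair. The next candidate is compound 3 `COc1ccc(S(=O)(=O)N2CCc3cccc(-c4cccnc4)c32)cc1`, which keeps the shared core and changes one group: pyridin-3-yl in place of 3-fluorophenyl on an aromatic carbon. Here, pyridin-3-yl takes the place of 3-fluorophenyl on an aromatic carbon.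

Within the data shown here, only one measured step bears on this change: a 2.3-fold higher number from compound 1 to compound 2 (0.36 log units; beyond the scatter). It also exchanged the group on that aromatic carbon, and it was modest. Among the measured compounds shown here, no measured compound yet carries a ring with a hetero atom there, so the direction is uncertain. A step no larger than that one is expected in this assay, perhaps toward a slightly higher number. The expected step is a 1.4-fold higher number from compound 2 to compound 3 (0.15 log units; within the scatter). For compound 3 the estimated value is 170 nM, with an expected range of 65 nM to 450 nM.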

Compound 3, half-maximal inhibitory concentration: 76.3 nM
For compound 3 the middle estimate is 2.2-fold (0.35 log units) above the measured one; measured number inside the range.
By their numbers in this assay, from the lowest: compounds 1, 3 and 2 (each within the scatter of the next, the first and the last beyond it).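

In this assay, pyridin-3-yl in place of 3-fluorophenyl gives a 1.6-fold lower number from compound 2 to compound 3 (0.19 log units; within the scatter), and pyridin-3-yl in place of 4-nitrophenyl gives a 1.5-fold higher number from compound 1 to compound 3 (0.17 log units; within the scatter). This aromatic carbon can therefore carry a six-membered aromatic ring with a hetero atom and a hydrogen-bond acceptor, and the number stays within the scatter of both carbon-only rings, even though those two rings lie beyond the scatter of each other. Nothing available explains why the three numbers fall as they do.

From the compounds shown here alone, all three compounds carry a six-membered aromatic ring at this carbon, so it remains open how a group with no such ring, such as an amine or a carboxylic acid, would read here. Also open, going by these compounds, is whether pyridin-2-yl or pyridin-4-yl would match pyridin-3-yl.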